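Cyclopentyl for cyclopropylmethyl on the diazepane nitrogen

The source may report more compounds than this note shows. Statements on the series, on what has been measured and on what is new or still open speak of the compounds shown alone.

Among the measured compounds shown here, compound 2 `Brc1ccc2ccn(CCN3CCCN(CC4CC4)CC3)c2c1` stands at the lowest of the two numbers measured so far; in an assay on HEK293 cells for binding affinity to 5-hydroxytryptamine receptor 7 (Homo sapiens), read by radioligand binding (a lower number here means a stronger inhibitor, a higher number a weaker inhibitor), compound 2 gives 9 nM, while compound 1 `CC(C)CN1CCCN(CCn2ccc3ccc(Br)cc32)CC1` gives 37 nM. For the measured compounds named here, the only measured step is a 4.1-fold lower number from compound 1 to compound 2 (0.61 log units; beyond the scatter), which concerns the group on the chain carbon bound to the ring nitrogen rather than a group bound to that nitrogen directly. Compound 3 `Brc1ccc2ccn(CCN3CCCN(C4CCCC4)CC3)c2c1` differs from compound 2 by cyclopentyl in place of cyclopropylmethyl on an amine nitrogen in a ring. Going by the values given here, no measured step covers a ring placed directly on the amine nitrogen, so the one step bears on this change only loosely, and no step beyond the scatter is expected in either direction. For compound 3 the number in this assay is estimated at 12 nM, within 4 nM to 40 nM, which would mean an expected step of a 1.3-fold higher number from compound 2 to compound 3 (0.12 log units; within the scatter).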

Compound 3, inhibition constant: 10 nM
Compound 3: middle estimate off by 1.2-fold (0.08 log units), on the high side; low and high end bracket the measured number.
By their numbers in this assay, from the lowest: compounds 2 and 3 (each within the scatter of the next); then compound 1.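

In this assay cyclopentyl and cyclopropylmethyl on the amine nitrogen in a ring cannot be told apart, with a 1.1-fold higher number from compound 2 to compound 3 (0.05 log units; within the scatter) showing that this position accepts a carbon ring bound directly to the nitrogen as readily as one carried on a single chain carbon. Against isobutyl, the same cyclopentyl gives a 3.7-fold lower number from compound 1 to compound 3 (0.57 log units; beyond the scatter) and so falls on the same side as cyclopropylmethyl, which makes the two ring-bearing groups differ from the one open-chain group here, though that rests on compound 1 alone. Nothing measured on these compounds gives a reason for either step.

Cyclobutyl and cyclohexyl on this nitrogen would show how far the ring size can move before the number shifts beyond the scatter. Going by these compounds, a tetrahydropyranyl ring or a plain secondary amine at the same place remains open too, as does any replacement of the bromine on the shared core.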